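Series notes: cyclopentylmethyl ether replacing the thiophene

A few compounds are considered here, and "the series" means these few. Any claim that something is new, unique, unknown or untested is made for them only; others in the source may bear on it.

Among the measured compounds shown here, compound 2 `O=C1N=C(O)S/C1=C\c1ccc(OCc2cccs2)cc1` holds the lower of the two numbers measured so far: in an assay for inhibition of 15-hydroxyprostaglandin dehydrogenase [NAD(+)] (Homo sapiens), read by fluorescence and spectrophotometry (a lower number here means a stronger inhibitor, a higher number a weaker inhibitor), compound 2 gives 287 nM, while compound 1 `Cc1ncsc1CCOc1ccc(/C=C2\SC(O)=NC2=O)cc1` gives 636 nM. For the measured compounds named here, the single measured step, a 2.2-fold lower number from compound 1 to compound 2 (0.35 log units; beyond the scatter), came with thiophen-2-yl replacing (4-methyl-1,3-thiazol-5-yl)methyl on a saturated chain carbon bound to an oxygen on an aromatic ring. Compound 3 `O=C1N=C(O)S/C1=C\c1ccc(OCCC2CCCC2)cc1` is the next member, and its change is cyclopentylmethyl in place of thiophen-2-yl on a saturated chain carbon bound to an oxygen on an aromatic ring. Going by these compounds, the measured step bears on this only in part: it shows that the group at that place moves the number modestly, but neither measured compound carries a non-aromatic ring there, so the swap from an aromatic ring to a carbon-only ring is untested. A step of at most modest size in this assay is therefore expected, with no firm direction, and the estimate for compound 3 is 380 nM, within 130 nM to 1100 nM, which amounts to a 1.3-fold higher number from compound 2 to compound 3 (0.12 log units; within the scatter).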

Compound 3, half-maximal inhibitory concentration: 116 nM
Compound 3: the middle estimate sits 3.3-fold (0.52 log units) above what was measured; measured number below the stated range.
By their numbers in this assay, from the lowest: compound 3; then compound 2; then compound 1.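

Compound 3 shows that neither an aromatic ring nor a sulfur atom is needed at this place: in this assay, cyclopentylmethyl in place of thiophen-2-yl gives a 2.5-fold lower number from compound 2 to compound 3 (0.39 log units; beyond the scatter) and the lowest number of the three. That step also changes the chain, since the same difference reads as (thiophen-2-yl)methyl to 2-cyclopentylethyl, so it does not isolate the ring. The cleaner ring comparison is a 5.5-fold lower number from compound 1 to compound 3 (0.74 log units; beyond the scatter) with cyclopentyl in place of 4-methyl-1,3-thiazol-5-yl, two bonds along the chain from the oxygen on the aromatic ring.

Going by these compounds, how much of the step from thiophen-2-yl comes from the ring and how much from the longer chain stays open. Also open, on these data alone, is whether a cyclohexyl ring or a piperidine ring would keep the number this low. No supporting evidence bears on the reason for these steps.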